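This account rests on a few compounds, and the source may have more. Where it says the series, first, only, none or still open, it means among the compounds named here.

In a physicochemical assay for solubility, measured as kinetic solubility (a higher number here means a more soluble compound, a lower number a less soluble compound), two compounds have been measured so far. Compound 1 `CNc1nc(C)c2cc(-c3cccc(CO)c3)c(=O)n(C3CCCC3)c2n1` gives 65000 nM, and compound 2 `COc1ccc(-c2cc3c(C)nc(N)nc3n([C@H]3CC[C@H](O)CC3)c2=O)cn1` gives 16000 nM. Compound 2 therefore holds the lower of the two numbers, and its gap to compound 1 is beyond the usual scatter of repeated measurements. These two compounds differ in more than one place, so their gap cannot be pinned on any single change. The next compound, compound 3 `COc1ccc(-c2cc3c(C)nc(N)nc3n([C@H]3CC[C@@H](O)CC3)c2=O)cn1`, departs from compound 2 only in its spatial arrangement: the two compounds have the same atoms and bonds and differ only in configuration as drawn: 2 of 2 stereo elements differ (all stereocentres are inverted: mirror images); a stereocentre at a saturated ring carbon is drawn r in compound 2 and s in compound 3; a stereocentre at a saturated ring carbon is drawn r in compound 2 and s in compound 3. Nothing leaves and nothing enters, as the two compounds have the same atoms and bonds. Within the data shown here, no measured pair here shows what such a change does, so no step beyond the scatter is expected, in either direction. The estimated step is a 1.1-fold higher number from compound 2 to compound 3 (0.05 log units; within the scatter). Compound 3 is expected at about 18000 nM, within an estimated range of 7000 nM to 50000 nM.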

Compound 3, solubility: 60000 nM
Compound 3: middle estimate off by 3.3-fold (0.52 log units), on the low side, outside the stated range (above it).
By their numbers in this assay, from the lowest: compound 2; then compounds 3 and 1 (each within the scatter of the next).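

In this assay, the two saturated ring carbons turn out to matter in their configuration as drawn, not only in which atoms are present, a point that the first two compounds, which differ in more than one place, could not show. Inverting both of them gives a 3.8-fold higher number from compound 2 to compound 3 (0.57 log units; beyond the scatter), a step that can be assigned to configuration alone because no atom or bond changes: the fact that compounds 2 and 3 differ only in the configuration as drawn. Among these compounds, this is the only measured pair of its kind here, so it shows the size of the step for this one core and set of groups.

Going by these compounds, it remains open whether the same inversion would give a similar step with other groups elsewhere on the core. On these data alone, it is also open whether a carboxylic acid in place of the hydroxyl group on the saturated ring would keep such a gap between its two configurations.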